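The compounds below may be only part of what the source reports. "The series", "measured", "known", "first", "only" and "open" are said of these compounds alone.

Measured compounds:
Compound 1, `FC(F)SCCc1ccccc1`, gives 3.16 in a physicochemical assay for lipophilicity, read by spectrophotometry, using the shake flask method, measured as octanol-water partition; on this read-out higher numbers stand for higher lipophilicity and lower numbers for lower lipophilicity.
Compound 2, `O=S(=O)(CCc1ccccc1)C(F)F`, gives 1.87 in this assay.

Of these two numbers, compound 2 carries the lower one. Its nearest neighbour is compound 1, whose value sits higher by a margin beyond the usual scatter. Within the data shown here, no single-point step between the two measured compounds has been worked out, so their values are read only as they stand side by side.

The account now follows the move from compound 2 to compound 3, `CS(=O)(=O)CCc1ccccc1`. The change is methyl in place of difluoromethyl on a sulfonyl sulfur. Among the measured compounds shown here, no measured pair in this set shows that particular change, so the size of the step cannot be taken from precedent. In this assay a modest fall is expected rather than none, clearly smaller than the gap that separates compound 2 from compound 1. The expected step is a number 0.42 log units lower from compound 2 to compound 3 (beyond the scatter). Compound 3 is accordingly estimated at 1.45, with a range from 1 to 1.9.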

Compound 3, partition coefficient: 0.82
Compound 3: middle estimate off by 0.63 log units, on the high side; the measured number lies below the stated range.
By their numbers in this assay, from the lowest: compound 3; then compound 2; then compound 1.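

With the sulfonyl sulfur held constant, the exchange of difluoromethyl for methyl is a large change in this assay and gives a number 1.05 log units lower from compound 2 to compound 3 (beyond the scatter), so the group on that sulfur moves the number by itself, which the earlier pair of compounds could not show. The wider replacement of (difluoromethyl)sulfanyl by methylsulfonyl on a saturated chain carbon gives a number 2.34 log units lower from compound 1 to compound 3 (beyond the scatter) and places compound 3 lowest of the three, although this step changes the group on the sulfur and the sulfur's substitution together and so cannot separate their shares. Nothing measured here explains why the exchange on the sulfonyl sulfur has this size.

The compounds shown leave open how a trifluoromethyl or an ethyl group would read on the same sulfonyl sulfur, and so whether the numbers follow any order across such groups. They also leave open whether the exchange of difluoromethyl for methyl would give a step of similar size in the sulfanyl series, where a methylsulfanyl group would complete the comparison with compound 1 in this assay and with compound 3 in the same assay.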